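From Trifluoromethyl to Chloro on the Benzylsulfanyl Ring

The source may report more compounds than this note shows. Statements on the series, on what has been measured and on what is new or still open speak of the compounds shown alone.

Compound 1 `C/C(C#Cc1ccccc1)=N\N/C(N)=N/S(=O)(=O)c1cc(C)c(Cl)cc1SCc1ccccc1` gives 110000 nM in a functional assay on MCF7 cells (Homo sapiens) for antiproliferative activity, read by MTT assay, with a stated time of 72 h; a higher number here means a weaker inhibitor, a lower number a stronger inhibitor. Compound 2 `C/C(C#Cc1ccccc1)=N\N/C(N)=N/S(=O)(=O)c1cc(C)c(Cl)cc1SCc1ccc(C(F)(F)F)cc1` gives 135000 nM and stands highest of the two numbers, its nearest neighbour being compound 1 through the step of a 1.2-fold higher number from compound 1 to compound 2 (0.09 log units; within the scatter). Compound 3 `C/C(C#Cc1ccccc1)=N\N/C(N)=N/S(=O)(=O)c1cc(C)c(Cl)cc1SCc1cccc(Cl)c1` carries the change (3-chlorophenyl in place of 4-(trifluoromethyl)phenyl on a saturated chain carbon bound to a sulfur). Among the measured compounds shown here, the only measured step, from compound 1 to compound 2, altered this same ring and stayed within the scatter, so the expected step is a 1.1-fold lower number from compound 2 to compound 3 (0.05 log units; within the scatter), none beyond the scatter. Compound 3 is therefore estimated at 120000 nM, with a range from 55000 nM to 260000 nM.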

Compound 3, half-maximal inhibitory concentration: 80000 nM
The estimate for compound 3 lay 1.5-fold (0.18 log units) above the measured number, within the range that was stated.
By their numbers in this assay, from the lowest: compounds 3, 1 and 2 (each within the scatter of the next).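

In this assay the swap of 4-(trifluoromethyl)phenyl for 3-chlorophenyl gives a 1.7-fold lower number from compound 2 to compound 3 (0.23 log units; within the scatter) and chloro in place of hydrogen on an aromatic carbon gives a 1.4-fold lower number from compound 1 to compound 3 (0.14 log units; within the scatter) and so neither step separates the compounds. This extends the earlier result to a second substituent, a chloro group, and to a second ring position, and the number still does not move beyond the scatter. From the compounds shown here alone, whether an amine or a carboxylic acid on this ring would shift the number stays open. No measurement available here bears on why these three numbers lie so close.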